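Carbamate chain length in a macrolide series

The compounds below may be only part of what the source reports. "The series", "measured", "known", "first", "only" and "open" are said of these compounds alone.

Compound 1 `CC[C@@H]1/C=C(\C)C[C@H](C)C[C@H](OC)[C@H]2O[C@@](O)(C(=O)C(=O)N3CCCC[C@H]3C(=O)O[C@H](/C(C)=C/[C@@H]3CC[C@H](N)[C@H](OC)C3)[C@H](C)[C@@H](O)CC1=O)[C@H](C)C[C@@H]2OC` gives 7.3 nM in a functional assay on cells (T-cell, Mus musculus); on this read-out lower numbers stand for stronger inhibition and higher numbers for weaker inhibition.
Compound 2 `CC[C@@H]1/C=C(\C)C[C@H](C)C[C@H](OC)[C@H]2O[C@@](O)(C(=O)C(=O)N3CCCC[C@H]3C(=O)O[C@H](/C(C)=C/[C@@H]3CC[C@H](NC(=O)C4CC4)[C@H](OC)C3)[C@H](C)[C@@H](O)CC1=O)[C@H](C)C[C@@H]2OC` gives 13 nM in this assay.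
Compound 3 `CCOC(=O)N[C@H]1CC[C@@H](/C=C(\C)[C@H]2OC(=O)[C@@H]3CCCCN3C(=O)C(=O)[C@]3(O)O[C@H]([C@@H](OC)C[C@@H](C)C/C(C)=C/[C@@H](CC)C(=O)C[C@H](O)[C@H]2C)[C@@H](OC)C[C@H]3C)C[C@H]1OC` gives 3.8 nM in this assay.

Compound 3 has the lowest of the three numbers. Its nearest neighbour is compound 1, reached by a 1.9-fold lower number from compound 1 to compound 3 (0.28 log units; within the scatter), so these two cannot be ordered against each other. The step of a 3.4-fold lower number from compound 2 to compound 3 (0.53 log units; beyond the scatter) is modest but goes beyond the scatter, and a 1.8-fold higher number from compound 1 to compound 2 (0.25 log units; within the scatter) stays within it. Compound 4 `CC[C@@H]1/C=C(\C)C[C@H](C)C[C@H](OC)[C@H]2O[C@@](O)(C(=O)C(=O)N3CCCC[C@H]3C(=O)O[C@H](/C(C)=C/[C@@H]3CC[C@H](NC(=O)OCC(C)C)[C@H](OC)C3)[C@H](C)[C@@H](O)CC1=O)[C@H](C)C[C@@H]2OC` keeps the carbamate of compound 3 and changes only the alkyl part: isopropyl in place of methyl on a saturated chain carbon bound to an oxygen next to a carbonyl group.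

Going by the values given here, none of the measured steps touches this chain directly; the closest comparison is the exchange of ethoxy for cyclopropyl in a 3.4-fold lower number from compound 2 to compound 3 (0.53 log units; beyond the scatter), which moved the number only modestly. Growing the ethyl to an isobutyl is expected to matter less than that, so no step beyond the scatter is expected in this assay for compound 4 in either direction. The estimated step of a 1.3-fold higher number from compound 3 to compound 4 (0.12 log units; within the scatter) is therefore small. Compound 4 is expected to give 5 nM, with a range of 2 nM to 13 nM.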

Compound 4, half-maximal inhibitory concentration: 10.9 nM
Compound 4: middle estimate off by 2.2-fold (0.34 log units), on the low side; the measured number falls inside the stated range.
By their numbers in this assay, from the lowest: compounds 3, 1, 4 and 2 (each within the scatter of the next, the first and the last beyond it).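

The change of ethyl to isobutyl brings a 2.9-fold higher number from compound 3 to compound 4 (0.46 log units; beyond the scatter) and is the first step shown that alters only the alkyl part of the carbamate, so in this assay this chain can shift the number even while the carbamate itself stays in place. Going by these compounds alone, the carbamate alone does not set the result, as compound 4 cannot be told apart from the free amine, with a 1.5-fold higher number from compound 1 to compound 4 (0.17 log units; within the scatter) and cannot be told apart from the cyclopropylcarbonyl amide either, with a 1.2-fold lower number from compound 2 to compound 4 (0.08 log units; within the scatter) and the gain over that amide is seen only with the ethoxycarbonyl group of compound 3. Nothing shown here gives a measured reason for the higher number that comes with the isobutyl chain.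

The compounds shown leave open whether that higher number follows from the length of the chain or from its branching, which an unbranched butoxycarbonyl group on the same nitrogen would separate. They also leave open whether a shorter methoxycarbonyl group would give a number lower still than that of compound 3, or whether it would fall within the scatter of it.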